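Inverting one chain stereocentre: compound 2 to compound 3

The source may hold more compounds than are shown below. What is called first, only, known or untested is meant among the compounds shown, and "the series" means these compounds.

For the measured compounds named here, compound 2 `O=C(O)CC/C=C\CCC[C@H]1[C@@H](O)CO[C@@H]1/C=C/[C@@H](O)COc1cccc(Cl)c1` gives 23 nM in a functional assay on NIH3T3 cells (Mus musculus) for activation of prostaglandin F2-alpha receptor (Homo sapiens), read by inositol phosphate accumulation (on this read-out lower numbers stand for an effect already at smaller amounts and higher numbers for an effect only at larger amounts of compound), the lowest of the two numbers measured so far; compound 1 `O=C(O)CCCC/C=C\C[C@H]1[C@@H](O)CO[C@@H]1/C=C/[C@@H](O)COc1cccc(C(F)(F)F)c1` gives 187 nM in this assay, a higher number with a gap beyond the scatter. Compound 3 `O=C(O)CC/C=C\CCC[C@H]1[C@@H](O)CO[C@@H]1/C=C/[C@H](O)COc1cccc(Cl)c1` remains to be measured. Relative to compound 2, (the two compounds have the same atoms and bonds and differ only in configuration as drawn: 1 of 6 stereo elements differ; a stereocentre at a saturated chain carbon is drawn R in compound 2 and S in compound 3). Going by the values given here, no measured pair shows a step of this kind, so the size of the step has no support in the present numbers. A step from compound 2 to compound 3 of a 13-fold higher number from compound 2 to compound 3 (1.12 log units; beyond the scatter) towards a higher number is expected. For compound 3 the estimate is 300 nM, with an expected range of 30 nM to 3000 nM.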

Compound 3, half-maximal effective concentration: 249 nM
Compound 3: middle estimate off by 1.2-fold (0.08 log units), on the high side; the measured number falls inside the stated range.
By their numbers in this assay, from the lowest: compound 2; then compounds 1 and 3 (each within the scatter of the next).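

In this assay, inverting a stereocentre at a saturated chain carbon from R to S gives an 11-fold higher number from compound 2 to compound 3 (1.03 log units; beyond the scatter). For the compounds shown here, this is the first measured pair that differs in one place, and it shows that configuration at this carbon matters on this read-out. The step can be assigned to this stereocentre alone because no atom or bond changes: the fact that compounds 2 and 3 differ only in the configuration as drawn

On these data alone, whether the same inversion gives a step of similar size with the trifluoromethyl group of compound 1 remains open. Also open, as far as these compounds go, is how a ketone or a methyl ether would compare with the hydroxyl at this carbon.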